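A few compounds are considered here, and "the series" means these few. Any claim that something is new, unique, unknown or untested is made for them only; others in the source may bear on it.

Among the measured compounds shown here, in an ADME assay for protein binding, using equilibrium dialysis, at pH 7.4, tested at 2 uM (on this read-out lower numbers stand for a smaller free fraction and higher numbers for a larger free fraction), compound 1 (`CC(C)N(C(=O)C1CCCCC1)c1cc(C#CC(C)(C)C)sc1C(=O)O`) gives 0.18 as the higher of the two numbers so far, and compound 2 (`CC(C)(C)C#Cc1cc(N(C(=O)[C@H]2CC[C@H](C)CC2)[C@H]2C[C@@H](Oc3cccnc3)C2)c(C(=O)O)s1`) gives 0.04 as the lower, a gap beyond the scatter. Compound 3 (`CC(C)N(C(=O)[C@H]1[C@@H]2CCCC[C@@H]21)c1cc(C#CC(C)(C)C)sc1C(=O)O`) is not yet measured and differs from compound 1 only in the group on the carbonyl carbon (a group of 7 heavy atoms (7 carbon; one three-membered non-aromatic ring of carbon only, one six-membered non-aromatic ring of carbon only) in place of a group of 6 heavy atoms (6 carbon; one six-membered non-aromatic ring of carbon only), on a carbonyl carbon). Compound 1 at 0.18 is the closest reference, and a small fall within the scatter is expected in this assay for this swap. The expected move is a 1.5-fold lower number from compound 1 to compound 3 (0.18 log units; within the scatter) in this series. For compound 3 the estimated value is 0.12 within a range of 0.06 to 0.22 on this read-out.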

Compound 3, unbound fraction: 0.04
Estimate against measurement, compound 3: 3.0-fold (0.48 log units) above; measured number outside the range, below it.
By their numbers in this assay, from the lowest: compounds 2 and 3 (each within the scatter of the next); then compound 1.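

In this assay, the group on the carbonyl carbon is a position that can move the read-out: exchanging cyclohexyl for the group with one three-membered and one six-membered carbon ring gives a 4.5-fold lower number from compound 1 to compound 3 (0.65 log units; beyond the scatter). Both groups contain only carbon, with no hydrogen-bond donors, acceptors or net charge, so a step of this size occurs without any change in those counts. Nothing available accounts for the step.

Open, on these data alone, is whether the step depends on the 3 defined stereocentres of the entering group. Also open, as far as these compounds go, is how a hydroxyl or an amine on that group would read.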